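A few compounds are considered here, and "the series" means these few. Any claim that something is new, unique, unknown or untested is made for them only; others in the source may bear on it.

Measured compounds in a functional assay on GBM2 cells (Homo sapiens) for antiproliferative activity, read by WST assay, with a stated time of 72 h; on this read-out higher numbers stand for weaker inhibition and lower numbers for stronger inhibition:
- compound 1, `O=C(Nc1ccc(C(F)(F)F)cc1)Nc1cc2ncncc2cc1OCc1cccc(F)c1`: 3200 nM
- compound 2, `O=C(Nc1ccc(C(F)(F)F)cc1)Nc1cc2ncncc2cc1OCc1cccc(Cl)c1`: 4700 nM

Among the measured compounds shown here, compound 2 has the highest of the two numbers so far in this assay, with compound 1 nearest at a distance given by a 1.5-fold higher number from compound 1 to compound 2 (0.17 log units; within the scatter), a step that stays within the scatter. The two measured compounds are therefore not separable on this read-out.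

Compound 3, `O=C(Nc1ccccc1F)Nc1cc2ncncc2cc1OCc1cccc(Cl)c1`, has not been measured in this assay. It differs from compound 2 in 2-fluorophenyl in place of 4-(trifluoromethyl)phenyl on an amide-type nitrogen. For the measured compounds named here, the only measured step, a 1.5-fold higher number from compound 1 to compound 2 (0.17 log units; within the scatter), concerns a different part of the molecule, the substituent on the benzyl ether, and does not touch the nitrogen where compound 3 changes. Going by the values given here, no measured step bears on the present change. The expectation for compound 3 therefore rests on compound 2 alone, and the size and direction of the change in this assay are undetermined from the numbers at hand; the step of a 1.3-fold higher number from compound 2 to compound 3 (0.11 log units; within the scatter) is estimated with a wide range to reflect that. Compound 3 is estimated at 6000 nM, within 1500 nM to 25000 nM.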

Compound 3, half-maximal inhibitory concentration: 4400 nM
The estimate for compound 3 lay 1.4-fold (0.13 log units) above the measured number; the measured number falls inside the stated range.
By their numbers in this assay, from the lowest: compounds 1, 3 and 2 (each within the scatter of the next).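

In this assay, 2-fluorophenyl in place of 4-(trifluoromethyl)phenyl on the amide-type nitrogen gives a 1.1-fold lower number from compound 2 to compound 3 (0.03 log units; within the scatter). Among the compounds shown here, this is the first reading at this position, as the earlier pair spoke only to the substituent on the benzyl ether: with the chloro group held constant, going from a group of 10 heavy atoms to one of 7 leaves the two compounds inseparable on this read-out. With a single step, this applies only to compound 2 and compound 3, and no available evidence accounts for it.

On these data alone, both groups compared here are six-membered aromatic rings of carbon only, with no hydrogen-bond donors or acceptors, so it remains open whether a group of a different kind on this nitrogen, such as a ring bearing an amine or a carboxylic acid, or a longer alkyl chain, would give a step beyond the scatter. Also open, as far as these compounds go, is whether 2-fluorophenyl would give a similar reading alongside the fluoro group of compound 1 on the benzyl ether.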